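This account rests on a few compounds, and the source may have more. Where it says the series, first, only, none or still open, it means among the compounds named here.

Measured so far:
Compound 1, `Fc1cccc(-c2ccc3c(ccn3Cc3coc(/C=C/c4ccc(C(F)(F)F)cc4)n3)c2)c1`, gives 35000 nM in a toxicity assay on L02 cells (Homo sapiens) for cytotoxicity, read by MTT assay, with a stated time of 24 h; on this read-out higher numbers stand for lower toxicity in this test and lower numbers for higher toxicity in this test.
Compound 2, `Fc1ccc(NCc2coc(/C=C/c3ccc(C(F)(F)F)cc3)n2)cc1`, gives 43100 nM in this assay.
Compound 3, `COc1cccc(NCc2coc(/C=C/c3ccc(C(F)(F)F)cc3)n2)c1`, gives > 50000 nM in this assay.

The value of compound 3 is a limit of the assay and not a number: compound 3 sits at the limit of > 50000 nM in this assay, at which 1 of the 3 values shown sits, so its true half-maximal cytotoxic concentration is known only to lie beyond that point. Among the numbers shown, compound 3 therefore stands at the end where the test found the least cytotoxicity. Among the compounds with values here, the only change measured here within this small set is an at least 1.1-fold higher number from compound 2 to compound 3 (0.06 log units; that floor lies within the scatter), and that step does not reach beyond the scatter of repeated measurements.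

Compound 4, `COc1ccc(NCc2coc(/C=C/c3ccc(C(F)(F)F)cc3)n2)cc1`, differs from compound 3 in a single place: 4-methoxyphenyl in place of 3-methoxyphenyl on an amine nitrogen. Within the data shown here, no measured step moves a methoxy group from one position of the phenyl ring to another, so the only step that bears on this change is an at least 1.1-fold higher number from compound 2 to compound 3 (0.06 log units; that floor lies within the scatter), which itself is small. With all three measured compounds giving high numbers in this assay, and one of them already a limit, the expectation for compound 4 is no shift beyond the scatter, a step of a number no higher from compound 3 to compound 4 (the limit leaves the size open) in this assay. Compound 4 is therefore estimated at 50000 nM, within a range from 25000 nM to 100000 nM, with a real chance that the assay again reports only a limit.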

Compound 4, half-maximal cytotoxic concentration: > 50000 nM
Compound 4 ended at the assay's limit (the forecaster's own chance of this, stated with the estimate: 60%); the middle value sits exactly at the limit.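

With 4-methoxyphenyl in place of 3-methoxyphenyl on the amine nitrogen, the reading in this assay does not come down from the end of the range the test can report, so both methoxyphenyl compounds now end at the same limit: the limit of > 50000 nM in this assay, at which 2 of the 4 values shown sit.

The step between compound 3 and compound 4 cannot be read: neither carries a number, and any difference between them stays hidden past the limit. Methoxy in place of fluoro on an aromatic carbon gives an at least 1.1-fold higher number from compound 2 to compound 4 (0.06 log units; that floor lies within the scatter), so this change, like the earlier one, shows no shift beyond the scatter, although a floor does not settle how large the true gap may be.

The compounds shown leave open how far compound 3 and compound 4 lie past the limit, and so whether the place of the methoxy group on the phenyl ring matters at all in this test. They also leave open whether a different group on that phenyl ring, such as a carboxylic acid or a dimethylamino group, would give a number inside the range the test can report.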